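Nitrogen substituent exchange from compound 2 to compound 3

This account rests on a few compounds, and the source may have more. Where it says the series, first, only, none or still open, it means among the compounds named here.

compound 1 `CCCCCCCn1ccc2cc(/C(C)=C/C(=O)Nc3ccccc3OCCCC(=O)O)ccc21` — 120 nM
compound 2 `CCCCCC(CCCCC)n1ccc2cc(/C(C)=C/C(=O)Nc3ccccc3OCCCC(=O)O)ccc21` — 25 nM

In an assay on Prostate gland for inhibition of steroid 5-alpha-reductase (Rattus norvegicus) (a higher number here means a weaker inhibitor, a lower number a stronger inhibitor), compound 2 holds the lowest of the two numbers; the nearest is compound 1, and a 4.8-fold lower number from compound 1 to compound 2 (0.68 log units; beyond the scatter). Compound 3 `C/C(=C\C(=O)Nc1ccccc1OCCCC(=O)O)c1ccc2c(ccn2Cc2ccccc2C)c1` differs from compound 2 in one place: 2-methylbenzyl in place of 1-pentylhexyl on an aromatic nitrogen. For the measured compounds named here, only that single step bears on this change, and it runs the other way, from a straight chain to the branched one. The new group is shorter and carries a ring, so a move back toward the number of compound 1 or past it is expected. Compound 3 is therefore expected near 100 nM, within 30 nM to 400 nM, which means a 4.0-fold higher number from compound 2 to compound 3 (0.60 log units; beyond the scatter) is expected.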

Compound 3, half-maximal inhibitory concentration: 69 nM
Compound 3: middle estimate off by 1.4-fold (0.16 log units), on the high side, and the stated range covers the measured number.
By their numbers in this assay, from the lowest: compound 2; then compounds 3 and 1 (each within the scatter of the next).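

In this assay this aromatic nitrogen also tolerates a ring-bearing group: a 2.8-fold higher number from compound 2 to compound 3 (0.44 log units; beyond the scatter) is a smaller loss than returning to the straight heptyl chain of compound 1. Replacing the hexyl part of that chain with 2-methylphenyl gives a 1.7-fold lower number from compound 1 to compound 3 (0.24 log units; within the scatter) and so no separable difference. Nothing available explains either step. Still open, on these data alone, is whether the methyl on the ring matters, as a plain benzyl group would show, and whether a shorter branched group such as 1-butylpentyl would hold the number of compound 2.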